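Iodo for Fluoro on the Aryl Ring of a Nucleoside

The compounds below may be only part of what the source reports. "The series", "measured", "known", "first", "only" and "open" are said of these compounds alone.

Measured compounds:
Compound 1 `OC[C@H]1O[C@@H](n2cnc3c(CSc4ccc(Cl)c(Cl)c4)ncnc32)[C@H](O)[C@@H]1O`: 224 nM
Compound 2 `OC[C@H]1O[C@@H](n2cnc3c(CSc4ccc(F)cc4)ncnc32)[C@H](O)[C@@H]1O`: 158 nM

Both compounds were tested in an assay on isolated protein for binding affinity to Equilibrative nucleoside transporter 1 (Homo sapiens); a higher number here means a weaker inhibitor, a lower number a stronger inhibitor. Compound 2 stands at the lower end of the two numbers shown, but the only step joining them, a 1.4-fold lower number from compound 1 to compound 2 (0.15 log units; within the scatter), lies within the scatter, so the two cannot be told apart.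

Compound 3 `OC[C@H]1O[C@@H](n2cnc3c(CSc4ccc(I)cc4)ncnc32)[C@H](O)[C@@H]1O` keeps the whole of compound 2 except for one change: iodo in place of fluoro on an aromatic carbon. Going by the values given here, the single measured step that bears on a halogen exchange on this aryl ring is the one from compound 1 to compound 2, and it stayed within the scatter. On that basis no step beyond the scatter is expected in this assay for compound 3, and the estimated step is a 1.1-fold lower number from compound 2 to compound 3 (0.02 log units; within the scatter). Compound 3 is therefore expected to give about 150 nM, with a range from 50 nM to 450 nM.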

Compound 3, half-maximal inhibitory concentration: 69.2 nM
The estimate for compound 3 lay 2.2-fold (0.34 log units) above the measured number; the range from low to high includes it.
By their numbers in this assay, from the lowest: compound 3; then compounds 2 and 1 (each within the scatter of the next).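

In this assay, going by these compounds alone, iodo in place of fluoro on the aromatic carbon gives the first step on this aryl ring that lies beyond the scatter, a 2.3-fold lower number from compound 2 to compound 3 (0.36 log units; beyond the scatter), so the identity of this single halogen does register here. The change from 3,4-dichlorophenyl to 4-iodophenyl on the sulfur also lies beyond the scatter, a 3.2-fold lower number from compound 1 to compound 3 (0.51 log units; beyond the scatter), whereas the change from 3,4-dichlorophenyl to 4-fluorophenyl did not separate its two compounds. No evidence at hand bears on this result.

The compounds shown leave open whether chloro or bromo alone at this place would stand with compound 2 or with compound 3, and whether a methoxy group or an amine would give a lower number still. They also leave open whether the same exchange would give a similar step with an oxygen in place of the sulfur.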